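From Methylsulfanyl to Diethylsulfamoyl on a Shared Core

This account rests on a few compounds, and the source may have more. Where it says the series, first, only, none or still open, it means among the compounds named here.

Of the compounds shown here, two on a shared core have been measured in an ADME assay on PC-3 cells (Homo sapiens) for cytotoxicity, read by WST assay, tested at 100 uM; on this read-out lower numbers stand for less inhibition and higher numbers for more inhibition at the one concentration tested (going by the name of the read-out). Compound 1 `O=C(Nc1ccc(Cl)cc1)C1CCCN(C(=O)c2cccc(-c3cccs3)c2)C1` gives 4% in this assay, and compound 2 `CSc1cccc(C(=O)N2CCCC(C(=O)Nc3ccc(Cl)cc3)C2)c1` gives 0% in this assay. Within the data shown here, the single measured step of a number 4 percentage points lower from compound 1 to compound 2 (within the scatter) is within the scatter, so the two values cannot be ordered. Compound 2 stands at the lowest of the two numbers, with compound 1 within the scatter of it.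

Compound 3 `CCN(CC)S(=O)(=O)c1cccc(C(=O)N2CCCC(C(=O)Nc3ccc(Cl)cc3)C2)c1` differs from compound 2 in one place: diethylsulfamoyl in place of methylsulfanyl on an aromatic carbon. Among the measured compounds shown here, no measured step involves a diethylsulfamoyl group. For the measured compounds named here, the only step available, a number 4 percentage points lower from compound 1 to compound 2 (within the scatter), concerns a different exchange at the same place and moved nothing beyond the scatter, and both measured numbers sit near the floor of the read-out. The expected step of a number 3 percentage points higher from compound 2 to compound 3 (within the scatter) is therefore none beyond the scatter. Compound 3 is expected to give 3% in this assay, with a range from 0% to 12% around it.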

Compound 3, a percentage reported as inhibition, at one concentration (the size of the read-out at that concentration, not a potency): 0%
Estimate against measurement, compound 3: 3 percentage points above; low and high end bracket the measured number.
By their numbers in this assay, from the lowest: compounds 2, 3 and 1 (each within the scatter of the next).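

In this assay there is no change at the digits printed from compound 2 to compound 3 (within the scatter), so on this aromatic carbon, meta to a large group, diethylsulfamoyl with its 8 heavy atoms stands in place of methylsulfanyl with its 2 heavy atoms, and the read-out does not separate the two. Against the third group measured at this place there is a number 4 percentage points lower from compound 1 to compound 3 (within the scatter), so thiophen-2-yl, methylsulfanyl and diethylsulfamoyl, which differ in size and in their atoms, now all give numbers within the scatter of one another, and the larger exchange adds a sulfonamide-bearing group to what the earlier pair had shown without moving the number beyond the scatter. No outside measurement bears on this result, so nothing can be said about what lies behind it.

As far as these compounds go, all three numbers sit near the floor of the read-out, so it remains open whether any group at this place, such as an amine or a carboxylic acid, would give a number beyond the scatter. From the compounds shown here alone, it is equally open whether an exchange elsewhere on the shared core, for instance of the chlorine on the anilide ring, would do so.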